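Shortening the Linker in an Oxazole Series: Cytotoxicity Estimate

The compounds below may be only part of what the source reports. "The series", "measured", "known", "first", "only" and "open" are said of these compounds alone.

Compound 1, `Fc1cccc(F)c1Cc1cnc(Nc2ccc(CCOc3ccncc3)cc2)o1`, gives 11000 nM in an ADME assay on MT2 cells (Homo sapiens) for cytotoxicity, read by MTT assay; a lower number here means that less compound is tolerated, a higher number that more compound is tolerated.
Compound 2, `Clc1cccc(Cl)c1Cc1nnc(Nc2ccc(COCc3ccccc3)cc2)o1`, gives 84000 nM in this assay.

Of the two measured compounds, compound 1 shows the lower number in this assay, and compound 2 the higher, a gap beyond the usual scatter. Compound 3, `Fc1cccc(F)c1Cc1cnc(Nc2ccc(COc3ccncc3)cc2)o1`, differs from compound 1 in one place: (pyridin-4-yl)oxy in place of ((pyridin-4-yl)oxy)methyl on a saturated chain carbon bound to an aromatic carbon. Among the measured compounds shown here, no measured pair shows this change, so the expected step from compound 1 to compound 3 is small, in no firm direction, and likely within the scatter. The estimated step is a 1.1-fold higher number from compound 1 to compound 3 (0.04 log units; within the scatter). Compound 3 is expected to give 12000 nM, with a range from 5000 nM to 30000 nM.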

Compound 3, half-maximal cytotoxic concentration: > 100000 nM
Compound 3 ended at the assay's limit (the forecaster's own chance of this, stated with the estimate: 15%); middle value at least 8.3-fold (0.92 log units) away from the limit.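

Cutting the chain at this place from 2-((pyridin-4-yl)oxy)ethyl to ((pyridin-4-yl)oxy)methyl, with the rest of the core of compound 1 unchanged, gives an at least 9.0-fold higher number from compound 1 to compound 3 (0.95 log units; beyond the scatter) in this assay. Among the compounds shown here, this is the first reading of a change in one place, and it shows that this chain position alone can move the result beyond the scatter. For compound 3, > 100000 nM is a limit of the assay and not a number, so the step marks only a lower bound on the change: the limit of > 100000 nM in this assay, at which 1 of the 3 values shown sits.

The compounds shown leave open how a longer chain, or an amine in place of the chain oxygen, would read in this assay. They also give no cause for the step.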